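Cyanobenzyl to Ester Arm: Following Compound 2 to 3

The source may hold more compounds than are shown below. What is called first, only, known or untested is meant among the compounds shown, and "the series" means these compounds.

In a functional assay on A549 cells (Homo sapiens) for cytotoxicity, read by MTT assay, with a stated time of 48 h (a lower number here means a stronger inhibitor, a higher number a weaker inhibitor), compound 2 `CCN(CC)c1ccc2cc(C(=O)c3ccc(N4CCN(C(=O)CN5CCN(Cc6ccc(C#N)cc6)CC5)CC4)cc3)oc2c1` gives 17400 nM, the lowest of the two numbers shown. Its nearest neighbour, compound 1 `CCN(CC)c1ccc2cc(C(=O)c3ccc(N4CCN(C(=O)CN5CCN(Cc6ccc(C(F)(F)F)cc6)CC5)CC4)cc3)oc2c1`, gives 20100 nM in this assay, and the step of a 1.2-fold lower number from compound 1 to compound 2 (0.06 log units; within the scatter) stays within the scatter. Compound 3 `CCOC(=O)CN1CCN(CC(=O)N2CCN(c3ccc(C(=O)c4cc5ccc(N(CC)CC)cc5o4)cc3)CC2)CC1` differs from compound 2 in one place: ethoxycarbonyl in place of 4-cyanophenyl on a saturated chain carbon bound to an amine nitrogen in a ring. For the measured compounds named here, the only measured step changed a group on the 4-cyanophenyl that now leaves entirely, so no measured step bears directly on this change; no shift beyond the scatter is expected from it. Compound 3 is therefore estimated at 20000 nM, between 8000 nM and 50000 nM, meaning a 1.1-fold higher number from compound 2 to compound 3 (0.06 log units; within the scatter).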

Compound 3, half-maximal inhibitory concentration: > 40000 nM
Compound 3 was reported as a limit; the forecaster's own chance of this, stated with the estimate: 15%; at least 2.0-fold (0.30 log units) between middle value and limit.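

Taking away the 4-cyanophenyl and putting ethoxycarbonyl on this saturated chain carbon gives an at least 2.2-fold higher number from compound 2 to compound 3 (0.36 log units; beyond the scatter), so in this assay a change at this place can move the number beyond the scatter, which the earlier swap on the aromatic ring did not do. Measured from the other benzyl compound, the change gives an at least 1.9-fold higher number from compound 1 to compound 3 (0.29 log units; that floor lies within the scatter). Compound 3 stands as a limit of the assay, > 40000 nM.

The compounds shown cannot separate losing the aromatic ring from gaining the ester. An unsubstituted phenyl or a carboxylic acid at this place would bear on that question.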